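The compounds below may be only part of what the source reports. "The series", "measured", "known", "first", "only" and "open" are said of these compounds alone.

Measured in a functional assay on MCF7 cells (Homo sapiens) for antiproliferative activity, read by MTT assay, with a stated time of 6 days; a lower number here means a stronger inhibitor, a higher number a weaker inhibitor:
compound 1, `CC(=O)O[C@@H]1C=CC(=O)O[C@@H]1[C@@H](COC(=O)c1ccc(Cl)cc1)OC(C)=O`, gives 2640 nM
compound 2, `O=C1C=C[C@@H](OCc2ccccc2)[C@@H]([C@@H](COC(=O)/C=C/c2ccccc2)OCc2ccccc2)O1`, gives 2570 nM

Compound 2 has the lower of the two numbers, but its nearest neighbour, compound 1, sits so close that the gap between them lies within the scatter of this kind of measurement. The two results are therefore best read as the same, and no order between compound 1 and compound 2 can be claimed from them.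

Compound 3, `O=C1C=C[C@@H](OCc2ccccc2)[C@@H]([C@@H](COC(=O)/C=C/c2ccc(F)cc2)OCc2ccccc2)O1`, has not yet been measured in this assay. Set beside compound 2 it shows a single change: fluoro in place of hydrogen on an aromatic carbon. Among the compounds with values here, no pair of measured compounds differs in just this way, so there is no measured step to lean on, and the expectation rests on the size of the change alone. One added fluorine at this spot is expected to shift the number only slightly, with no step beyond the scatter in either direction, estimated as a 1.1-fold lower number from compound 2 to compound 3 (0.05 log units; within the scatter). For compound 3 in this assay the estimate is 2300 nM, with a range from 1000 nM to 5500 nM.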

Compound 3, half-maximal inhibitory concentration: 3010 nM
Estimate against measurement, compound 3: 1.3-fold (0.12 log units) below, and the stated range covers the measured number.
By their numbers in this assay, from the lowest: compounds 2, 1 and 3 (each within the scatter of the next).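

In this assay, within the data shown here, this is the first comparison in the set between two compounds that differ in one place, and it gives a 1.2-fold higher number from compound 2 to compound 3 (0.07 log units; within the scatter) for the change from phenyl to 4-fluorophenyl. Compound 2 and compound 3 are therefore best read as the same, which shows that this aromatic carbon, para to a large group, can carry a fluoro group in place of hydrogen with no readable shift in antiproliferative activity. No supporting measurement is available to explain this result.

The compounds shown leave open whether a chloro group, a methoxy group, an amine or a carboxylic acid on this same carbon would give a step beyond the scatter, since a single fluoro group is the only replacement for hydrogen seen here. Compound 1 differs from compound 2 and from compound 3 in more than one place, so it cannot show which part of the structure, if any, governs the activity of this series.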